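The source may hold more compounds than are shown below. What is called first, only, known or untested is meant among the compounds shown, and "the series" means these compounds.

Among the compounds with values here, compound 1 `CCOc1ccc(-n2nncc2CN2C(=O)C3(C(C#N)=C(N)Oc4c3c3nc5ccccc5nc3c3ccccc43)c3ccccc32)cc1` and compound 2 `N#CC1=C(N)Oc2c(N)cc3nc4ccccc4nc3c2C12C(=O)N(Cc1cnnn1-c1ccc(F)cc1)c1ccccc12` share a large fused core and are the only two compounds with numbers here. In a functional assay on MCF7 cells (Homo sapiens) for antiproliferative activity, read by MTT assay, with a stated time of 48 h (on this read-out higher numbers stand for weaker inhibition and lower numbers for stronger inhibition), compound 1 gives > 50000 nM, which is a limit of the assay rather than a measured number. In this assay compound 2 likewise gives > 50000 nM, again a limit and not a value. Compound 2 therefore stands at the edge of what this assay can report, and the same holds for both values shown (the limit of > 50000 nM in this assay, at which 2 of the 2 values shown sit). Compound 3 `CCc1cccc(C)c1-n1nncc1CN1C(=O)C2(C(C#N)=C(N)Oc3c(N)cc4nc5ccccc5nc4c32)c2ccccc21` keeps the core of compound 2 and changes only the group on the five-membered aromatic ring with 3 nitrogen: 2-ethyl-6-methylphenyl in place of 4-fluorophenyl on an aromatic nitrogen. Within the data shown here, no step between two measured compounds is available, so the size of such a change cannot be read from any pair of numbers, and nothing is known about what the 2-ethyl-6-methylphenyl group does to activity. Among the measured compounds shown here, with the only measured neighbour sitting at a limit, no step beyond the scatter is expected, the estimated step being a number no higher from compound 2 to compound 3 (the limit leaves the size open) in this assay. For compound 3 the estimate in this assay is 50000 nM, with a range from 20000 nM to 100000 nM, most likely reported again only as a limit.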

Compound 3, half-maximal inhibitory concentration: > 50000 nM
Compound 3: only a limit was reported; the forecaster's own chance of this, stated with the estimate: 80%; the middle value lies on the limit itself.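

In this assay compound 3 gives > 50000 nM, a limit and not a number. Compound 2 also sits at a limit, so no step between compound 2 and compound 3 can be read: the limit of > 50000 nM in this assay, at which 3 of the 3 values shown sit.

The compounds shown leave open whether 2-ethyl-6-methylphenyl in place of 4-fluorophenyl changes activity at all, and what activity any of them has beyond the limit.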